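A few compounds are considered here, and "the series" means these few. Any claim that something is new, unique, unknown or untested is made for them only; others in the source may bear on it.

Measured so far in an ADME assay on MT4 cells (Homo sapiens) for cytotoxicity, read by MTT assay, with a stated time of 96 h; on this read-out lower numbers stand for higher toxicity in this test and higher numbers for lower toxicity in this test:
- compound 1 `Fc1ccc(F)c(/N=N/c2ccc(NC[C@@H]3CCCN4CCCC[C@H]34)c3c2CCCC3)c1`: 40000 nM
- compound 2 `CN1CCN(/N=N/c2ccccc2)CC1`: 65000 nM

Compound 1 stands at 40000 nM and compound 2 at 65000 nM on this read-out. These two values lie within the usual scatter of each other, so neither compound stands apart from the other.

The next compound is compound 3 `Fc1ccc(/N=N/c2ccc(NC[C@@H]3CCCN4CCCC[C@H]34)c3c2CCCC3)c(F)c1`, which keeps the core of compound 1. The change is 2,4-difluorophenyl in place of 2,5-difluorophenyl on a double-bonded nitrogen. The two compounds have the same atoms, joined differently.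

Going by the values given here, no two measured compounds differ in one place, so the series offers no measured step as a guide for this change. The expectation therefore rests on compound 1 at 40000 nM and on the unchanged atom count. No step beyond the scatter is expected, and the estimated step of a 1.1-fold lower number from compound 1 to compound 3 (0.02 log units; within the scatter) is small, with no firm direction. Compound 3 is expected at 38000 nM (estimated range 16000 nM to 85000 nM).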

Compound 3, half-maximal cytotoxic concentration: 51000 nM
For compound 3 the middle estimate is 1.3-fold (0.13 log units) below the measured one; the range from low to high includes it.
By their numbers in this assay, from the lowest: compounds 1, 3 and 2 (each within the scatter of the next).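

In this assay, placing 2,4-difluorophenyl in place of 2,5-difluorophenyl on a double-bonded nitrogen gives a 1.3-fold higher number from compound 1 to compound 3 (0.11 log units; within the scatter) and supplies the first step the series can read at this position. The two compounds have the same atoms, joined differently, and the leaving and entering groups match in every count given, so this step isolates the arrangement of the two fluorines on the phenyl ring, and that rearrangement does not separate the pair on this read-out. This holds for this single pair only, and nothing available bears on the reason for the result.

The compounds shown leave open whether a group of another kind at this position, such as a phenyl ring carrying a carboxylic acid, a primary amine or a nitrile, would give a step beyond the scatter. They also leave open whether a change elsewhere on the shared core, such as a longer chain in place of the linking carbon before the amine nitrogen, would move the number in this assay.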